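Metabolic stability of oxazole piperidine amides: a dimethylphenyl step

A few compounds are considered here, and "the series" means these few. Any claim that something is new, unique, unknown or untested is made for them only; others in the source may bear on it.

Measured so far:
compound 1 `Cc1oc(-c2ccc(F)cc2)nc1CN1CCC(C(=O)NCCCN2C[C@H](C)C[C@H](C)C2)CC1` — 0.468 h
compound 2 `Cc1oc(-c2c(Br)cccc2Br)nc1CN1CCC(C(=O)NCCCN2C[C@H](C)C[C@H](C)C2)CC1` — 0.035 h
compound 3 `COc1cccc(Br)c1-c1nc(CN2CCC(C(=O)NCCCN3C[C@H](C)C[C@H](C)C3)CC2)c(C)o1` — 0.0583 h

In an ADME assay on microsomes from liver (Rattus norvegicus) for metabolic stability, read by LC-MS, using NADPH, at 37 degrees C (on this read-out higher numbers stand for a longer-lived compound and lower numbers for a shorter-lived compound), compound 3 stands second highest of the three numbers; its nearest neighbour is compound 2, with a 1.7-fold higher number from compound 2 to compound 3 (0.22 log units; within the scatter), while compound 1 lies furthest, with an 8.0-fold lower number from compound 1 to compound 3 (0.90 log units; beyond the scatter). Compound 4 `Cc1ccc(-c2nc(CN3CCC(C(=O)NCCCN4C[C@H](C)C[C@H](C)C4)CC3)c(C)o2)c(C)c1` arises from compound 3 by 2,4-dimethylphenyl in place of 2-bromo-6-methoxyphenyl on an aromatic carbon. Among the compounds with values here, no measured step covers this exact change; the steps that bear on it are a 13-fold lower number from compound 1 to compound 2 (1.13 log units; beyond the scatter) and an 8.0-fold lower number from compound 1 to compound 3 (0.90 log units; beyond the scatter), both large drops from compound 1. Compound 4 is therefore expected to sit between compound 3 and compound 1, which means a 3.4-fold higher number from compound 3 to compound 4 (0.54 log units; beyond the scatter). The estimate for compound 4 is 0.2 h, with a range from 0.05 h to 0.8 h.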

Compound 4, half-life: > 0.5 h
Compound 4 gave a limit, no number; the forecaster's own chance of this, stated with the estimate: 5%; middle value at least 2.5-fold (0.39 log units) from the limit.
By their numbers in this assay, from the lowest: compounds 2 and 3 (each within the scatter of the next); then compound 1. At a limit, above all of these: compound 4.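

For compound 4 the half-life is a limit and not a number: > 0.5 h. The earlier changes at this position only lowered the number, yet a phenyl bearing two groups need not do so, with an at least 8.5-fold higher number from compound 3 to compound 4 (0.93 log units; beyond the scatter) and an at least 14-fold higher number from compound 2 to compound 4 (1.15 log units; beyond the scatter). Against the 4-fluorophenyl group the reading is an at least 1.0-fold higher number from compound 1 to compound 4 (0.02 log units; that floor lies within the scatter), so no clear gain over compound 1 can be claimed.

From the compounds shown here alone, how far the true half-life of compound 4 lies past its limit stays open. The compounds shown also leave open whether a single methyl group, a chloro group or a pyridine ring would serve equally well here.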